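Swapping ethyl for 2-hydroxyethoxy on an amide-type nitrogen

This account rests on a few compounds, and the source may have more. Where it says the series, first, only, none or still open, it means among the compounds named here.

- Compound 1 `O=C(Nc1cccc(Cl)c1)N1CCc2[nH]nc(C(=O)N3CCCCO3)c2C1` gives 38 mL/min/kg
- Compound 2 `CN(OC1COC1)C(=O)c1n[nH]c2c1CN(C(=O)Nc1cccc(Cl)c1)CC2` gives 8 mL/min/kg
- Compound 3 `CCN(C)C(=O)c1n[nH]c2c1CN(C(=O)Nc1cccc(Cl)c1)CC2` gives 87 mL/min/kg
- Compound 4 `CN(OCCO)C(=O)c1n[nH]c2c1CN(C(=O)Nc1cccc(Cl)c1)CC2` has not yet been measured

In an ADME assay on microsomes from liver (Homo sapiens) for metabolic stability (on this read-out lower numbers stand for slow clearance and higher numbers for fast clearance), compound 3 gives 87 mL/min/kg and stands highest of the three measured compounds, with compound 1 nearest and compound 2 furthest. The change that leads to compound 4 is 2-hydroxyethoxy in place of ethyl on an amide-type nitrogen and in words it puts 2-hydroxyethoxy in place of ethyl on an amide-type nitrogen.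

The closest measured comparison is an 11-fold higher number from compound 2 to compound 3 (1.04 log units; beyond the scatter) which is large and beyond the scatter and concerns ethyl and (oxetan-3-yl)oxy on such a nitrogen. Read backwards, it suggests a lower number when an oxy group replaces ethyl. The step of a 2.3-fold higher number from compound 1 to compound 3 (0.36 log units; beyond the scatter) is modest but points the same way, and none of the three compounds goes against this. Within the data shown here, the step of a 4.8-fold lower number from compound 1 to compound 2 (0.68 log units; beyond the scatter) shows that groups of this kind can still differ from one another, and no measured compound carries 2-hydroxyethoxy. A large step to a lower number is therefore expected, though its size is uncertain.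

The estimated change is a 6.7-fold lower number from compound 3 to compound 4 (0.83 log units; beyond the scatter) in this assay on this reasoning. For compound 4 the expected value is 13 mL/min/kg with an estimated range from 5 mL/min/kg to 32 mL/min/kg in this read-out.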

Compound 4, clearance: 31 mL/min/kg
Beside the measured number, compound 4's estimate is 2.4-fold (0.38 log units) below it; the range from low to high includes it.
By their numbers in this assay, from the lowest: compound 2; then compounds 4 and 1 (each within the scatter of the next); then compound 3.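

In this assay, 2-hydroxyethoxy on this amide-type nitrogen also gives a lower number than ethyl (a 2.8-fold lower number from compound 3 to compound 4 (0.45 log units; beyond the scatter)), so the direction seen with (oxetan-3-yl)oxy now holds for a second oxy group, one without a ring. The two oxy groups are not interchangeable, however: with 2-hydroxyethyl in place of oxetan-3-yl on the oxygen, the number goes up (a 3.9-fold higher number from compound 2 to compound 4 (0.59 log units; beyond the scatter)), which shows that an oxygen on this nitrogen does not alone set the clearance and that the group it carries also counts. The open-chain group of compound 4 and the six-membered ring of compound 1 leave the read-out within the scatter (a 1.2-fold lower number from compound 1 to compound 4 (0.09 log units; within the scatter)), and compound 2 remains the lowest of the four. Nothing in the data shown accounts for these differences.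

The compounds shown leave open whether the hydroxyl of 2-hydroxyethoxy plays any part in the result, a question that a plain methoxy or ethoxy group on this nitrogen would address. Also open, on these data alone, is how a longer chain on the oxygen, or an amine in place of that hydroxyl, would read in this assay.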